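The source may report more compounds than this note shows. Statements on the series, on what has been measured and on what is new or still open speak of the compounds shown alone.

Measured compounds: compound 1 `S=C(N/N=C/c1ccccc1)N1CCNCC1` gives 63000 nM in a functional assay on HL-60 cells (Homo sapiens) for antiproliferative activity, with a stated time of 48 h; a lower number here means a stronger inhibitor, a higher number a weaker inhibitor; compound 3 `C/C(=N\NC(=S)N1CCNCC1)c1cccc([N+](=O)[O-])c1` gives 62000 nM in this assay; for compound 2 `C/C(=N/NC(=S)N1CCNCC1)c1ccccc1` the entry in this assay reads "not determined" (no result reported), so no result is reported for it.

On these numbers compound 1 stands highest of the two, with compound 3 nearest, the two lying within the scatter of each other. Compound 4 `Oc1ccc(/C=N/NC(=S)N2CCNCC2)cc1` differs from compound 1 by hydroxy in place of hydrogen on an aromatic carbon. Among the compounds with values here, no step between measured compounds that would show the effect of such a change is available, so compound 4 is expected to stay near compound 1, with a step in this assay of a 1.3-fold lower number from compound 1 to compound 4 (0.10 log units; within the scatter) that need not exceed the scatter. Compound 4 is therefore estimated at 50000 nM, within the range 15000 nM to 170000 nM.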

Compound 4, half-maximal inhibitory concentration: 50000 nM
Compound 4: the middle estimate sits on the measured number at the digits printed; low and high end bracket the measured number.
By their numbers in this assay, from the lowest: compounds 4, 3 and 1 (each within the scatter of the next).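

Hydroxy in place of hydrogen on an aromatic carbon, para to a large group, gives the first step between measured compounds in this assay, with a 1.3-fold lower number from compound 1 to compound 4 (0.10 log units; within the scatter). This single change therefore does not separate compound 4 from compound 1 beyond the scatter. No measurement at hand bears on the reason for this result.

From the compounds shown here alone, whether an amine, a carboxylic acid or a methoxy group at this position would give a step beyond the scatter stays open. So does the outcome for hydroxy elsewhere on the ring.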